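A few compounds are considered here, and "the series" means these few. Any claim that something is new, unique, unknown or untested is made for them only; others in the source may bear on it.

- compound 1 `O=C(CCc1cccc2c1B(O)OC2)Nc1cccc(-c2ccccc2)c1`: 12000 nM
- compound 2 `O=C(CCc1cccc2c1B(O)OC2)Nc1cccc(-c2cccc(Cl)c2)c1`: 58000 nM

In an ADME assay on WI-38 cells (Homo sapiens) for cytotoxicity, read by MTT assay, with a stated time of 72 h (on this read-out higher numbers stand for weaker inhibition and lower numbers for stronger inhibition), compound 2 gives the higher of the two numbers, at 58000 nM. The next compound, compound 3 `O=C(CCc1cccc2c1B(O)OC2)Nc1cccc(-c2cccc(OC(F)(F)F)c2)c1`, has trifluoromethoxy in place of chloro on an aromatic carbon. Among the measured compounds shown here, only one measured step bears on this change, and it is a modest one: a 4.8-fold higher number from compound 1 to compound 2 (0.68 log units; beyond the scatter). That step adds chloro in place of hydrogen on an aromatic carbon, whereas compound 3 swaps the chloro for another group. For the measured compounds named here, no measured pair shows such a swap, so the evidence is thin, and no clear change beyond the scatter is expected in this assay. The expected step is a 1.2-fold lower number from compound 2 to compound 3 (0.06 log units; within the scatter). For compound 3 the estimated value is 50000 nM, with an expected range from 20000 nM to 120000 nM.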

Compound 3, half-maximal inhibitory concentration: 9800 nM
Estimate against measurement, compound 3: 5.1-fold (0.71 log units) above, and the stated range ends above it.
By their numbers in this assay, from the lowest: compounds 3 and 1 (each within the scatter of the next); then compound 2.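

In this assay the higher number seen with chloro does not carry over to the other substituent tried at this place: there is a 5.9-fold lower number from compound 2 to compound 3 (0.77 log units; beyond the scatter), which undoes the earlier rise. Against the unsubstituted parent, there is a 1.2-fold lower number from compound 1 to compound 3 (0.09 log units; within the scatter), so adding trifluoromethoxy leaves the number where it was, and chloro alone stands apart among these three compounds. Heavy-atom count does not follow the numbers here, as trifluoromethoxy brings 5 heavy atoms and chloro brings 1, and no measurement shown accounts for the difference between the two groups.

As far as these compounds go, it remains open whether chloro is a lone case at this place or whether a methyl group, a methoxy group or an amine would give a similar rise. Whether these groups would behave the same way with a longer chain before the amide is also unsettled.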